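Shortening the chain while keeping the methyl thiourea

A few compounds are considered here, and "the series" means these few. Any claim that something is new, unique, unknown or untested is made for them only; others in the source may bear on it.

Compound 3 `C/N=C(\S)NCCCCn1nc(-c2ccccc2)ccc1=O` stands highest of the three numbers in a functional assay on the whole organism with Rattus norvegicus as the target, at a dose of 100 mg/kg; a higher number here means more inhibition at the dose given (going by the name of the read-out), a lower number less inhibition: in this assay compound 3 gives 87.1%. Its nearest neighbour compound 1 `CC/N=C(\S)NCCCCCn1nc(-c2ccccc2)ccc1=O` gives 66.4% in this assay, so that a number 20.7 percentage points higher from compound 1 to compound 3 (beyond the scatter). The furthest, compound 2 `CC/N=C(\S)NCCCn1nc(-c2ccccc2)ccc1=O`, gives 39% in this assay, and a number 48.1 percentage points higher from compound 2 to compound 3 (beyond the scatter).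

Compound 4 `C/N=C(\S)NCCCn1nc(-c2ccccc2)ccc1=O` has not been measured in this assay. It differs from compound 3 in one place: a group of 5 heavy atoms (2 carbon, 2 nitrogen, 1 sulfur; no ring) in place of a group of 6 heavy atoms (3 carbon, 2 nitrogen, 1 sulfur; no ring), on a saturated chain carbon, three bonds along the chain from an aromatic nitrogen.

Among the measured compounds shown here, two measured steps bear on this change. a number 27.4 percentage points lower from compound 1 to compound 2 (beyond the scatter) is a chain shortening alone, with the ethyl group kept, and it lowered the read-out, though by two carbons rather than one. a number 48.1 percentage points higher from compound 2 to compound 3 (beyond the scatter) combines chain lengthening with the exchange of ethyl for methyl; compound 4 undoes the chain part of that step while keeping methyl, so only a portion of that large step should be given back. a number 20.7 percentage points higher from compound 1 to compound 3 (beyond the scatter) likewise mixes both changes and does not isolate the chain.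

The step from compound 3 to compound 4 is therefore expected to be a fall, a number 21.1 percentage points lower from compound 3 to compound 4 (beyond the scatter), modest and beyond the scatter. Compound 4 is expected to give 66% in this assay, within a range of 42% to 88%.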

Compound 4, a percentage reported as inhibition, in the whole organism at one dose (the size of the read-out at that dose, not a potency): 38.9%
For compound 4 the middle estimate is 27.1 percentage points above the measured one; the measured number lies below the stated range.
By their numbers in this assay, from the lowest: compounds 4 and 2 (each within the scatter of the next); then compound 1; then compound 3.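

In this assay, among the compounds shown here, with the methyl thiourea end kept, the group of 5 heavy atoms in place of the group of 6 heavy atoms gives a number 48.2 percentage points lower from compound 3 to compound 4 (beyond the scatter), so the chain change at this position carries a large effect on its own, which no earlier step isolated. At the shorter chain the end group makes no resolved difference, with a number 0.1 percentage points lower from compound 2 to compound 4 (within the scatter) for hydrogen in place of methyl on the saturated chain carbon bound to a double-bonded nitrogen, while a number 27.5 percentage points lower from compound 1 to compound 4 (beyond the scatter) sets this low level against the longer ethyl compound but mixes the chain and the end group. Nothing at hand explains why the read-out responds so strongly to this chain change.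

Still open, on these data alone, is whether the end group matters at the chain of compound 3, since the ethyl thiourea on that chain does not appear, and whether a longer chain with the methyl end would hold the read-out. Equally open, as far as these compounds go, is how a propyl group on the thiourea, or a urea with oxygen in place of sulfur, would behave on that chain.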